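A Methyl for Methoxy Swap on the Shared Core

A few compounds are considered here, and "the series" means these few. Any claim that something is new, unique, unknown or untested is made for them only; others in the source may bear on it.

Compound 1, `COc1ccccc1-c1nc2ncccc2o1`, was tested in a functional assay on the whole organism for inhibition, with Rattus norvegicus as the target, at a dose of 30 mg/kg (on this read-out higher numbers stand for more inhibition at the one dose given (going by the name of the read-out) and lower numbers for less inhibition), and compound 1 gave 9%. Its close relative compound 2, `COc1cccc(-c2nc3ncccc3o2)c1`, gave 14% in this assay; the two values lie within the usual scatter of each other, so compound 1 is not set apart from compound 2 on these numbers. Compound 3, `Cc1ccccc1-c1nc2ncccc2o1`, differs from compound 1 by methyl in place of methoxy on an aromatic carbon. For the measured compounds named here, no measured pair shows a change of this kind, so the expected step is a number 1 percentage points higher from compound 1 to compound 3 (within the scatter), judged to stay within the scatter. For compound 3 the estimate is 10%, with a range from 0% to 28%.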

Compound 3, a percentage reported as inhibition, in the whole organism at one dose (the size of the read-out at that dose, not a potency): 0%
Beside the measured number, compound 3's estimate is 10 percentage points above it; measured number inside the range.
By their numbers in this assay, from the lowest: compounds 3, 1 and 2 (each within the scatter of the next, the first and the last beyond it).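

Methyl in place of methoxy on an aromatic carbon, ortho to a group of 9 heavy atoms, gives a number 9 percentage points lower from compound 1 to compound 3 (within the scatter) in this assay. This first step at this position shows that methoxy, with its hydrogen-bond acceptor, can leave without a shift beyond the scatter, so these numbers do not separate the two groups here. Nothing measured offers a reason for this result. Still open, as far as these compounds go, is whether an amine or a carboxylic acid on this carbon would move the number beyond the scatter.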